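Butyl for 4-methylphenyl on a peptide-linked thiazolidinedione

A few compounds are considered here, and "the series" means these few. Any claim that something is new, unique, unknown or untested is made for them only; others in the source may bear on it.

Measured compounds:
compound 1 `CCCC[C@H](NC(=O)[C@H](CCCCN)NC(=O)[C@H](CCCNC(=N)N)NC(=O)c1ccc(/C=C/C(N)=O)cc1)C(N)=O` — "impermeable" (no number reported)
compound 2 `CCCC[C@H](NC(=O)[C@H](CCCCN)NC(=O)[C@H](CCCNC(=N)N)NC(=O)c1ccccc1)C(N)=O` — "impermeable" (no number reported)
compound 3 `CCCC[C@H](NC(=O)[C@H](CCCCN)NC(=O)[C@H](CCCNC(=N)N)NC(=O)c1ccc(/C=C2\SC(=O)N(c3ccc(C)cc3)C2=O)cc1)C(N)=O` — 0.66 10^-6 cm/s

Of the three measured compounds, only compound 3 carries a number in an ADME assay for permeability, using PAMPA; on this read-out lower numbers stand for lower permeability and higher numbers for higher permeability: compound 3 gives 0.66 10^-6 cm/s. Compound 1 is recorded in this assay only as "impermeable" (no number reported). Compound 2 likewise is recorded only as "impermeable" (no number reported), so neither offers a figure against which compound 3 can be placed.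

Compound 4 `CCCC[C@H](NC(=O)[C@H](CCCCN)NC(=O)[C@H](CCCNC(=N)N)NC(=O)c1ccc(/C=C2\SC(=O)N(CCCC)C2=O)cc1)C(N)=O` differs from compound 3 in one place: butyl in place of 4-methylphenyl on an amide-type nitrogen in a ring. For the measured compounds named here, no pair of measured compounds shows this change in isolation, so its effect is not known from the data. In this assay the step from compound 3 to compound 4 is expected to be small, a 1.3-fold lower number from compound 3 to compound 4 (0.12 log units; within the scatter), no larger than the scatter. Compound 4 is therefore estimated at 0.5 10^-6 cm/s, within 0.2 10^-6 cm/s to 1.2 10^-6 cm/s.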

Compound 4, apparent permeability: 1.18 10^-6 cm/s
The estimate for compound 4 lay 2.4-fold (0.37 log units) below the measured number; the range from low to high includes it.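

In this assay, butyl in place of 4-methylphenyl on the amide-type nitrogen in the ring gives a 1.8-fold higher number from compound 3 to compound 4 (0.25 log units; within the scatter) and thus no step beyond the scatter. At this position, a chain with no ring and 4 heavy atoms can therefore replace the six-membered aromatic ring, and the result is still a numerical reading rather than the "impermeable" record of compounds 1 and 2. No available evidence bears on the reason for this result.

The compounds shown leave open how a longer chain on this nitrogen would read. They also leave open how an amine or a carboxylic acid at the end of such a chain would read.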